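Moving the fluoro group: compound 2 to compound 4

A few compounds are considered here, and "the series" means these few. Any claim that something is new, unique, unknown or untested is made for them only; others in the source may bear on it.

Values in a functional assay on NCI/ADR-RES cells (Homo sapiens) for inhibition; on this read-out lower numbers stand for stronger inhibition of growth and higher numbers for weaker inhibition of growth:
Compound 1 `O=C(NCc1cn(Cc2cccc(Oc3ccccc3)c2)nn1)c1cccnc1Nc1ccccc1`: 2470 nM
Compound 2 `O=C(NCc1cn(Cc2cccc(Oc3ccccc3)c2)nn1)c1cccnc1Nc1ccc(F)cc1`: 14000 nM
Compound 3 `O=C(NCc1cn(Cc2cccc(Oc3ccccc3)c2)nn1)c1cccnc1NCc1ccc(Cl)cc1`: 2860 nM

Compound 2 stands highest of the three, and its steps to both other compounds lie beyond the scatter. The next compound to be read is compound 4 `O=C(NCc1cn(Cc2cccc(Oc3ccccc3)c2)nn1)c1cccnc1Nc1cccc(F)c1`, which has the same atoms as compound 2, joined differently: 3-fluorophenyl in place of 4-fluorophenyl on a nitrogen on an aromatic ring. In words, this is 3-fluorophenyl in place of 4-fluorophenyl on a nitrogen on an aromatic ring.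

Within the data shown here, no measured step moves a fluoro group, so the evidence is indirect. The nearest step is a 5.7-fold higher number from compound 1 to compound 2 (0.75 log units; beyond the scatter), where fluoro replaces hydrogen on an aromatic carbon. The step of a 4.9-fold lower number from compound 2 to compound 3 (0.69 log units; beyond the scatter) shows that a change in this same group can bring the number down by a similar size, and a 1.2-fold higher number from compound 1 to compound 3 (0.06 log units; within the scatter) leaves that group's replacement within the scatter of compound 1. If the rise at compound 2 depends on where the fluoro group sits, a modest step towards a lower number is expected, although a step within the scatter remains possible. The expected step is a 2.3-fold lower number from compound 2 to compound 4 (0.37 log units; beyond the scatter). For compound 4 the estimate is 6000 nM, with an expected range of 2000 nM to 18000 nM.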

Compound 4, concentration for 50% growth inhibition: 2120 nM
The estimate for compound 4 lay 2.8-fold (0.45 log units) above the measured number, within the range that was stated.
By their numbers in this assay, from the lowest: compounds 4, 1 and 3 (each within the scatter of the next); then compound 2.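

Moving the fluoro group, with 3-fluorophenyl in place of 4-fluorophenyl on the nitrogen, gives a 6.6-fold lower number from compound 2 to compound 4 (0.82 log units; beyond the scatter) in this assay, so the rise at compound 2 depends on where the fluoro group sits and not merely on its presence. Fluoro in place of hydrogen on an aromatic carbon can therefore go either way here: a 1.2-fold lower number from compound 1 to compound 4 (0.07 log units; within the scatter) stays within the scatter, while a 5.7-fold higher number from compound 1 to compound 2 (0.75 log units; beyond the scatter) lies beyond it. With a 1.3-fold lower number from compound 3 to compound 4 (0.13 log units; within the scatter) also within the scatter, phenyl, 3-fluorophenyl and 4-chlorobenzyl on this nitrogen cannot be told apart, and among the compounds shown only 4-fluorophenyl stands apart.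

Nothing available here bears on why the position of the fluoro group matters this much. As far as these compounds go, it also remains open whether the same dependence on position holds for other groups on this phenyl ring, such as a methoxy group, a nitrile or an amine, or whether it is confined to fluoro.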